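This account rests on a few compounds, and the source may have more. Where it says the series, first, only, none or still open, it means among the compounds named here.

Compound 1 `CCn1c(C(=O)NCCCN(C)C)ccc1C(CC)(CC)c1ccc(OCC(O)C(C)(C)C)c(C)c1`: 3100 nM
Compound 2 `CCN(CC)CCCNC(=O)c1ccc(C(CC)(CC)c2ccc(OCC(O)C(C)(C)C)c(C)c2)n1CC`: 2500 nM
Compound 3 `C#CCNC(=O)c1ccc(C(CC)(CC)c2ccc(OCC(O)C(C)(C)C)c(C)c2)n1CC`: 16200 nM

These values come from a functional assay on PC-3 cells (Homo sapiens), read by MTT assay, with a stated time of 48 h; a lower number here means a stronger inhibitor, a higher number a weaker inhibitor. Compound 3, at 16200 nM, has the highest number of the three, and its steps to both others lie beyond the scatter. Compound 4 `CCn1c(C(=O)N(C)CCC#N)ccc1C(CC)(CC)c1ccc(OCC(O)C(C)(C)C)c(C)c1` has not yet been measured. It differs from compound 3 by (2-cyanoethyl)(methyl)amino in place of propargylamino on a carbonyl carbon.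

Among the compounds with values here, no measured step makes this exchange, so the evidence is indirect. The two steps closest to it are a 5.2-fold higher number from compound 1 to compound 3 (0.72 log units; beyond the scatter) and a 6.5-fold higher number from compound 2 to compound 3 (0.81 log units; beyond the scatter), both modest, in which a chain ending in dimethylamino or diethylamino gives way to the propargyl group. Swapping between those two amines mattered little, as shown by a 1.2-fold lower number from compound 1 to compound 2 (0.09 log units; within the scatter). Compound 4 carries neither amine, and its chain ends in a nitrile, as the propargyl chain of compound 3 ends in a triple bond. Within the data shown here, with only three compounds, this is a weak guide, and the loss of the amide hydrogen is untested. In this assay, no step beyond the scatter is therefore expected, in either direction. The expected change is a 1.2-fold lower number from compound 3 to compound 4 (0.06 log units; within the scatter). Compound 4 is estimated at 14000 nM, with an expected range of 5500 nM to 35000 nM.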

Compound 4, half-maximal inhibitory concentration: 1700 nM
Beside the measured number, compound 4's estimate is 8.2-fold (0.92 log units) above it; the whole stated range lies above it.
By their numbers in this assay, from the lowest: compounds 4, 2 and 1 (each within the scatter of the next); then compound 3.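

In this assay, the exchange on a carbonyl carbon gives a 9.5-fold lower number from compound 3 to compound 4 (0.98 log units; beyond the scatter), so a chain ending in a triple bond does not fix the number at this position, since both the entering and the leaving group carry one. The earlier compounds shown here left open whether a terminal dimethylamino or diethylamino group was needed for the lower numbers, but (2-cyanoethyl)(methyl)amino has neither amine and still falls within the scatter of both, with a 1.5-fold lower number from compound 2 to compound 4 (0.17 log units; within the scatter) and a 1.8-fold lower number from compound 1 to compound 4 (0.26 log units; within the scatter). No measurement shown here accounts for this result.

The exchange changes two things at once, removing the amide hydrogen and altering the chain, so the compounds shown cannot say which of these matters; (2-cyanoethyl)amino, which keeps the amide hydrogen, and (methyl)(propargyl)amino, which lacks it, would separate the two. Going by these compounds, it also remains open how far this tolerance extends at the carbonyl carbon, for instance to a longer chain ending in a nitrile or to a chain ending in a carboxylic acid.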